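Fluoro additions on the aryl group, writhing inhibition notes

The source may hold more compounds than are shown below. What is called first, only, known or untested is meant among the compounds shown, and "the series" means these compounds.

Measured so far:
compound 1 `Cc1c(/C=N\O)cc(-c2ccc(S(C)(=O)=O)cc2)n1-c1cccc(F)c1` gives 32% in a functional assay on the whole organism (strain Swiss albino) for inhibition, with Mus musculus as the target, in the writhing test, with a stated time of 30 min, at a dose of 10 mg/kg by the oral route; on this read-out lower numbers stand for a weaker effect and higher numbers for a stronger effect at the one dose given
compound 2 `Cc1c(/C=N\O)cc(-c2ccc(S(C)(=O)=O)cc2)n1-c1ccccc1` gives 27% in this assay
compound 3 `Cc1c(C#N)cc(-c2ccc(S(C)(=O)=O)cc2)n1-c1cccc(F)c1` gives 28% in this assay

The three numbers sit close together. The change fluoro in place of hydrogen on an aromatic carbon gives a number 5 percentage points higher from compound 2 to compound 1 (within the scatter), so nothing beyond the usual scatter is seen from it. The step of a number 4 percentage points lower from compound 1 to compound 3 (within the scatter) is likewise small. Compound 3 and compound 2 differ in more than one place, and the difference between their two cores is not broken down here; their values show only that they lie within the scatter of each other.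

Compound 4 `Cc1c(C#N)cc(-c2ccc(S(C)(=O)=O)cc2)n1-c1ccc(F)c(F)c1` has not been measured in this assay. It differs from compound 3 by fluoro in place of hydrogen on an aromatic carbon. This is the same kind of change as fluoro in place of hydrogen on an aromatic carbon, but not the same: in compound 1 the entering group sits meta to a large group, whereas in compound 4 it sits ortho to a fluoro group and para to a large group.

Within the data shown here, only one measured instance of this kind of change exists, and it gave a number 5 percentage points higher from compound 2 to compound 1 (within the scatter), a step within the scatter. On that basis the expected step from compound 3 to compound 4 is a number 3 percentage points higher from compound 3 to compound 4 (within the scatter), small and of similar size. Compound 4 is therefore estimated at 31%, with a likely range from 18% to 44%.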

Compound 4, a percentage reported as inhibition, in the whole organism at one dose (the size of the read-out at that dose, not a potency): 19%
Beside the measured number, compound 4's estimate is 12 percentage points above it; measured number inside the range.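

Fluoro in place of hydrogen on an aromatic carbon, here taking 3-fluorophenyl to 3,4-difluorophenyl, gives in this assay a number 9 percentage points lower from compound 3 to compound 4 (within the scatter), so on this core too the change produces no step beyond the usual scatter. The two instances of the change cannot be told apart, and nothing here indicates that its outcome depends on the core: the same change on two cores in this assay, a number 5 percentage points higher (within the scatter) from compound 2 to compound 1 and a number 9 percentage points lower (within the scatter) from compound 3 to compound 4, 14 percentage points apart, within the scatter of two such steps

This does not show that the change carries over unaltered: there are only two instances, their cores differ, and the entering fluoro does not stand in the same place in both, so a real dependence on core or place, small enough to be lost in the scatter, remains possible.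

The compounds shown vary only the fluoro pattern on the aryl group and the choice of oxime or nitrile, and each is read at one oral dose, so it remains open whether any of these differences would emerge across a range of doses. Also open, going by these compounds, is how the series responds to a chloro or methoxy group on the aryl group, an amide or carboxylic acid in place of the nitrile, or a longer chain in place of the methyl group.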